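Cytotoxicity notes on a nitroimidazooxazine series

The source may report more compounds than this note shows. Statements on the series, on what has been measured and on what is new or still open speak of the compounds shown alone.

Measured compounds:
- compound 1 `O=[N+]([O-])c1cn2c(n1)OC(COc1ncc(-c3ccc(F)cc3)cn1)CC2`: in an ADME assay on MRC5 cells (Homo sapiens) for cytotoxicity, read by resazurin assay, with a stated time of 72 h (a lower number here means a stronger inhibitor, a higher number a weaker inhibitor), compound 1 gives > 64000 nM, a limit of the assay.
- compound 2 `O=[N+]([O-])c1cn2c(n1)OC(COc1cccc(-c3ccc(F)cc3)n1)CC2`: in this assay compound 2 gives 59000 nM.
- compound 3 `O=[N+]([O-])c1cn2c(n1)OC(COc1ncc(-c3ccc(F)nc3)cn1)CC2`: in this assay compound 3 gives > 64000 nM, again a limit.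

Within the data shown here, compound 2 holds the only number in the set; the other two values are limits. The difference between the core of compound 1 and the core of compound 2 is not broken down here. Compound 1 and compound 3 differ by 6-fluoropyridin-3-yl in place of 4-fluorophenyl on an aromatic carbon, and this gives a step that the two limits leave unreadable from compound 1 to compound 3; the reason the step cannot be read is the limit of > 64000 nM in this assay, at which 2 of the 3 values shown sit.

Compound 4 `O=[N+]([O-])c1cn2c(n1)OC(COc1cccc(-c3ccc(F)nc3)n1)CC2` is not yet measured. It differs from compound 2 by 6-fluoropyridin-3-yl in place of 4-fluorophenyl on an aromatic carbon. This is the same kind of change as from compound 1 to compound 3, but the surroundings differ: in compound 2 the place is on an aromatic carbon of a six-membered aromatic ring with 1 nitrogen, next to the ring nitrogen, meta to a large group, whereas in compound 1 it is on a ring with 2 nitrogen, two atoms from the ring nitrogen, para to a large group.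

For compound 4 the expected step in this assay is a 1.2-fold higher number from compound 2 to compound 4 (0.07 log units; within the scatter), resting on compound 2 at 59000 nM and on the unreadable step from compound 1 to compound 3. Compound 4 is estimated at 70000 nM, between 35000 nM and 150000 nM, with a fair chance that only a limit is reported.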

Compound 4, half-maximal inhibitory concentration: 35000 nM
Estimate against measurement, compound 4: 2.0-fold (0.30 log units) above; the range from low to high includes it.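

In this assay, putting 6-fluoropyridin-3-yl in place of 4-fluorophenyl on the core of compound 2 gives a 1.7-fold lower number from compound 2 to compound 4 (0.23 log units; within the scatter), so on this core the change leaves the cytotoxicity read-out where repeated measurements would scatter anyway. Whether this result carries over from one core to the other cannot be judged, because the same change on the core of compound 1 gives no readable step, with both values there being limits and not numbers: the limit of > 64000 nM in this assay, at which 2 of the 4 values shown sit. The series therefore offers a single readable pair, which shows that the change is tolerated in this one setting, on an aromatic carbon next to the ring nitrogen, but does not establish a rule for the change across cores.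

The compounds shown leave open whether an amine or a carboxylic acid in place of the fluorine of 6-fluoropyridin-3-yl, or a longer chain between the shared core and the aromatic ring, would move the number in this assay beyond the scatter. They also leave open whether such a group on the core of compound 1 would give a number rather than a limit, which would make a comparison between the two cores possible.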